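Hydroxy in Place of Nitro: Expected Antiproliferative Potency

This account rests on a few compounds, and the source may have more. Where it says the series, first, only, none or still open, it means among the compounds named here.

Three analogues sharing one core have been tested in a functional assay on HCT-116 cells (Homo sapiens) for antiproliferative activity, read by MTT assay, with a stated time of 24 h; a lower number here means a stronger inhibitor, a higher number a weaker inhibitor. Compound 1 `COc1ccc(C(=O)/C=C/c2ccc3ccccc3c2)c2c1C=CC(C)(C)O2` gives 5820 nM, and compound 2 `COc1ccc(C(=O)/C=C/c2ccc([N+](=O)[O-])cc2)c2c1C=CC(C)(C)O2` gives 8880 nM, the higher of the two numbers, though the two lie within the scatter of each other. For compound 3 `COc1ccc(C(=O)/C=C/c2ccc(OC)c(OC)c2OC)c2c1C=CC(C)(C)O2` this assay reports only a limit, > 10000 nM (the limit of > 10000 nM in this assay, at which 1 of the 3 values shown sits). Compound 4 `COc1ccc(C(=O)/C=C/c2ccc(O)cc2)c2c1C=CC(C)(C)O2` has not yet been measured; it differs from compound 2 by hydroxy in place of nitro on an aromatic carbon. Among the measured compounds shown here, no step between measured compounds is available to calibrate this change, so its size is open; with all measured neighbours weak, the expected step of a 1.3-fold lower number from compound 2 to compound 4 (0.10 log units; within the scatter) is one within the scatter, with the direction uncertain. Compound 4 is therefore estimated at 7000 nM, with a range from 2500 nM to 20000 nM.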

Compound 4, half-maximal inhibitory concentration: > 10000 nM
Compound 4 was reported as a limit (the forecaster's own chance of this, stated with the estimate: 30%); middle value at least 1.4-fold (0.15 log units) away from the limit.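

Hydroxy in place of nitro on the aromatic carbon now has a step of its own in this assay, which reads an at least 1.1-fold higher number from compound 2 to compound 4 (0.05 log units; that floor lies within the scatter) and is only a floor. Compound 4 gives > 10000 nM and this is a limit, not a number. The 4-hydroxyphenyl compound thus offers no measurable gain over the 4-nitrophenyl one, and the limit is now shared by compound 3 and compound 4: the limit of > 10000 nM in this assay, at which 2 of the 4 values shown sit.

On these data alone, how far compound 4 lies past that limit remains open. So does whether an amine or a carboxylic acid at this position would give a lower number.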